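This account rests on a few compounds, and the source may have more. Where it says the series, first, only, none or still open, it means among the compounds named here.

Two compounds built on a shared core were measured in an assay on cells for displacement of a labelled ligand from adenosine receptor A3 (Homo sapiens), read by scintillation counting and radioligand binding, with a stated time of 180 min, tested at 10 uM (a higher number here means more inhibition at the concentration tested (going by the name of the read-out), a lower number less inhibition), and a third awaits its measurement. Among the measured compounds shown here, compound 1 `Cn1cnc2c(N3CCCCC3)nc(-c3ccccc3O)nc21` gives 20% in this assay, the lowest of the two numbers known so far. Compound 2 `CN1CCN(c2nc(-c3cccc(O)c3)nc3c2ncn3C)CC1` gives 63.8% in this assay, and its number lies beyond the scatter on the higher side of the number for compound 1. Compound 3 `Cn1cnc2c(N3CCCCC3)nc(-c3cccc(O)c3O)nc21` has not yet been measured. It differs from compound 1 in a single place: hydroxy in place of hydrogen on an aromatic carbon. For the measured compounds named here, no step between two measured compounds shows what this particular change does, so its direction cannot be read from the data at hand. A modest rise in this assay is expected for the step of a number 10 percentage points higher from compound 1 to compound 3 (within the scatter), of a size close to the edge of the scatter. Compound 3 is therefore estimated to give 30% in this assay, with a range from 5% to 60%.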

Compound 3, a percentage reported as inhibition, at one concentration (the size of the read-out at that concentration, not a potency): 33.7%
The estimate for compound 3 lay 3.7 percentage points below the measured number; measured number inside the range.
By their numbers in this assay, from the lowest: compound 1; then compound 3; then compound 2.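

Placing a hydroxy group on the aromatic carbon ortho to the existing hydroxy group, which turns 2-hydroxyphenyl into 2,3-dihydroxyphenyl, gives in this assay a number 13.7 percentage points higher from compound 1 to compound 3 (beyond the scatter) and is the first single-place step available in this set. It shows that this carbon can carry a hydroxy group without loss of inhibition at the concentration tested, and that here the change moves the number modestly upward. Nothing measured here gives a reason for this rise.

The compounds shown leave open whether a methoxy group, an amine or a carboxylic acid on this same carbon would move the number in the same direction, or whether hydroxy is particular in this respect. They also leave open whether the step would look the same without the hydroxy group ortho to this carbon.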